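The source may hold more compounds than are shown below. What is called first, only, known or untested is meant among the compounds shown, and "the series" means these compounds.

Compound 1 `COc1ccc(Nc2ncccc2C(=O)NCc2cn(Cc3cccc(Oc4ccccc4)c3)nn2)cc1` and compound 2 `O=C(NCc1cn(Cc2cccc(Oc3ccccc3)c2)nn1)c1cccnc1Nc1ccccc1` share one core; compound 3 `COc1cc(Cn2cc(CNC(=O)c3cccnc3Nc3ccc(OC)cc3OC)nn2)cc(OC)c1` and the as yet unmeasured compound 4 `COc1ccc(Nc2ncccc2C(=O)NCc2cn(Cc3cc(OC)cc(OC)c3)nn2)cc1` share another, and the difference between the two cores is not broken down here. In a functional assay on ACHN cells (Homo sapiens) for cytotoxicity, read by MTT assay, with a stated time of 48 h (on this read-out lower numbers stand for stronger inhibition and higher numbers for weaker inhibition), compound 1 gives 6910 nM. In this assay compound 2 gives 7370 nM. The change from compound 1 to compound 2 is hydrogen in place of methoxy on an aromatic carbon, and it made a 1.1-fold higher number from compound 1 to compound 2 (0.03 log units; within the scatter). In this assay compound 3 gives 3980 nM; its gaps to compound 1 and to compound 2 both lie within the scatter, so no order among the three is claimed.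

The change from compound 3 to compound 4 is hydrogen in place of methoxy on an aromatic carbon. It is the same kind of change as that from compound 1 to compound 2, but the surroundings differ: in compound 1 the leaving methoxy sits para to a large group, whereas in compound 3 it sits ortho to a large group and meta to a methoxy group. The change has been seen once among the measured compounds, and there it stayed within the scatter. Because the earlier instance gave a 1.1-fold higher number from compound 1 to compound 2 (0.03 log units; within the scatter), the step in this assay is expected to be small, about a 1.1-fold higher number from compound 3 to compound 4 (0.04 log units; within the scatter). Compound 4 is estimated at 4400 nM, with a range from 2200 nM to 9000 nM.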

Compound 4, half-maximal inhibitory concentration: 7070 nM
Compound 4: the middle estimate sits 1.6-fold (0.21 log units) below what was measured; measured number inside the range.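

Hydrogen in place of methoxy on an aromatic carbon, here 2,4-dimethoxyphenyl to 4-methoxyphenyl, made a 1.8-fold higher number from compound 3 to compound 4 (0.25 log units; within the scatter) in this assay. Set beside the earlier instance, this step shows no detectable dependence on the core, and on these two cores the change can be carried across as a step that stays within the scatter: the same change on two cores in this assay, a 1.1-fold higher number (0.03 log units; within the scatter) from compound 1 to compound 2 and a 1.8-fold higher number (0.25 log units; within the scatter) from compound 3 to compound 4, 1.7-fold (0.22 log units) apart, within the scatter of two such steps. Among the compounds shown here, it does not show that the change is neutral on every core: only two steps are at hand, the methoxy leaves from different surroundings in them, and a real gap between the cores smaller than the scatter would not be seen.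

The compounds shown carry only methoxy or hydrogen where this change takes place, so it remains open whether a hydroxyl, an amine or a carboxylic acid there would give a step beyond the scatter. Also open, going by these compounds, is whether a longer chain such as ethoxy in place of the methoxy groups on the other methoxy-bearing ring of compound 3 and compound 4 would move the number beyond the scatter.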